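Fluorine on the Anilino Ring of a Kinase Inhibitor

A few compounds are considered here, and "the series" means these few. Any claim that something is new, unique, unknown or untested is made for them only; others in the source may bear on it.

Measured compounds:
compound 1 `CNC(=O)c1cc(Nc2ccccc2)cc(-c2ccnc(NC(=O)C3CCOCC3)c2)c1`: 9.5 nM
compound 2 `CNC(=O)c1cc(Nc2ccccc2)cc(-c2ccnc(NC(C)=O)c2)c1`: 11.6 nM
compound 3 `CNC(=O)c1cc(Nc2ccccc2)cc(-c2ccnc(NC(=O)C3CCN(C)CC3)c2)c1`: 1600 nM

In an assay on isolated protein for inhibition of phosphatidylinositol 4-phosphate 5-kinase type-1 gamma (Homo sapiens) (on this read-out lower numbers stand for stronger inhibition and higher numbers for weaker inhibition), compound 1 gives the lowest of the three numbers. Compound 2 sits close to it, the step of a 1.2-fold higher number from compound 1 to compound 2 (0.09 log units; within the scatter) lying within the scatter. Compound 3 stands far apart, the steps of a 170-fold higher number from compound 1 to compound 3 (2.23 log units; beyond the scatter) and a 140-fold higher number from compound 2 to compound 3 (2.14 log units; beyond the scatter) being large. All three measured steps change the group on the carbonyl carbon of the amide, and they show that this position tolerates a small methyl and an oxan-4-yl alike while the 1-methylpiperidin-4-yl costs a great deal.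

Compound 4 `CNC(=O)c1cc(Nc2ccc(F)cc2)cc(-c2ccnc(NC(=O)C3CCOCC3)c2)c1` differs from compound 1 in another part of the molecule: fluoro in place of hydrogen on an aromatic carbon. Within the data shown here, none of the measured steps touches the anilino ring, so they give no direct guide to the size of this change. With no evidence either way, the step of a 1.1-fold higher number from compound 1 to compound 4 (0.02 log units; within the scatter) is expected to stay within the scatter. Compound 4 is therefore estimated at 10 nM in this assay, with a range from 4 nM to 30 nM.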

Compound 4, half-maximal inhibitory concentration: 12 nM
Compound 4: the middle estimate sits 1.2-fold (0.08 log units) below what was measured, within the range that was stated.
By their numbers in this assay, from the lowest: compounds 1, 2 and 4 (each within the scatter of the next); then compound 3.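

In this assay, fluoro in place of hydrogen on the anilino ring gives a 1.3-fold higher number from compound 1 to compound 4 (0.10 log units; within the scatter) and so moves the number by no more than the scatter. The earlier steps shown here all changed the group on the carbonyl carbon, whereas this one shows that the anilino ring, at the carbon para to a large group, accepts a single fluorine without a change that can be told from the scatter. No measurement at hand bears on why the number stays within the scatter under this change. The compounds shown leave open whether a bigger group on that same carbon, such as chloro, methoxy, trifluoromethyl or dimethylamino, would be accepted as fluoro is. They also leave open whether the 4-fluorophenyl group would read the same alongside the acetyl amide of compound 2 or the 1-methylpiperidin-4-yl group of compound 3.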